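Swapping Chloro for Methyl on the Phenyl Ring

A few compounds are considered here, and "the series" means these few. Any claim that something is new, unique, unknown or untested is made for them only; others in the source may bear on it.

Two measured compounds share one core and differ only in a single group on the outer phenyl ring. Compound 1 `O=C(Nc1ccc2cc(CN3CCCC3)cnc2c1)N1CCC(c2ccc(F)cc2)CC1` carries fluoro there, and compound 2 `O=C(Nc1ccc2cc(CN3CCCC3)cnc2c1)N1CCC(c2ccc(Cl)cc2)CC1` carries chloro. In an assay on CHO cells for displacement of a labelled ligand from melanin-concentrating hormone receptor 1 (Homo sapiens), read by scintillation counting, with a stated time of 1 h (on this read-out higher numbers stand for weaker inhibition and lower numbers for stronger inhibition), compound 1 gives 35 nM and compound 2 gives 6.6 nM. The step of a 5.3-fold lower number from compound 1 to compound 2 (0.72 log units; beyond the scatter) is a clear gain, so compound 2 stands with the lowest number of the two, and compound 1 is the nearest, higher beyond the scatter.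

Compound 3 `Cc1ccc(C2CCN(C(=O)Nc3ccc4cc(CN5CCCC5)cnc4c3)CC2)cc1` is the next variation: methyl in place of chloro on an aromatic carbon. Among the measured compounds shown here, no measured step covers this exact exchange; the one step available, a 5.3-fold lower number from compound 1 to compound 2 (0.72 log units; beyond the scatter), only shows that this position responds to a change of group. The move from chloro to methyl is therefore expected to produce, in this assay, a step of a 1.5-fold higher number from compound 2 to compound 3 (0.18 log units; within the scatter), within or close to the scatter. Compound 3 is estimated at 10 nM, with a likely range from 4 nM to 30 nM.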

Compound 3, half-maximal inhibitory concentration: 23 nM
Compound 3: the middle estimate sits 2.3-fold (0.36 log units) below what was measured, within the range that was stated.
By their numbers in this assay, from the lowest: compound 2; then compounds 3 and 1 (each within the scatter of the next).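

In this assay, methyl does not match chloro at this position (the exchange gives a 3.5-fold higher number from compound 2 to compound 3 (0.54 log units; beyond the scatter)). Methyl and fluoro cannot be told apart (the comparison gives a 1.5-fold lower number from compound 1 to compound 3 (0.18 log units; within the scatter)), so among the three groups shown, chloro alone stands apart, something the earlier pair of compounds could not reveal, since it left open whether any group other than fluoro would bring the same gain. Nothing available here explains why chloro differs from the other two groups.

The compounds shown leave open whether bromo, methoxy or trifluoromethyl at this position would fall nearer to chloro or nearer to methyl and fluoro. They also leave open how an amine or a carboxylic acid would behave in the same place on the phenyl ring.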